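This account rests on a few compounds, and the source may have more. Where it says the series, first, only, none or still open, it means among the compounds named here.

Of the compounds shown here, three sharing one core have been tested in a functional assay on HCT-116 cells (Homo sapiens) for antiproliferative activity, read by MTT assay, with a stated time of 72 h; on this read-out higher numbers stand for weaker inhibition and lower numbers for stronger inhibition. Compound 1 `Cc1cccc(CSc2cc(Cl)c(C)cc2S(=O)(=O)/N=C(\N)N/N=C/C#Cc2ccccc2)c1` gives 18000 nM in this assay, compound 2 `Cc1cc(S(=O)(=O)/N=C(\N)N/N=C/C#Cc2ccccc2)c(SCc2ccccc2C(F)(F)F)cc1Cl` gives 18000 nM, and compound 3 `Cc1cc(S(=O)(=O)/N=C(\N)N/N=C/C#Cc2ccccc2)c(SCc2ccc(C(F)(F)F)cc2)cc1Cl` gives 70000 nM. The three differ only in the aromatic group on a saturated chain carbon bound to a sulfur. Among the three numbers, that of compound 3 is the highest: a 3.9-fold higher number from compound 1 to compound 3 (0.59 log units; beyond the scatter), and a 3.9-fold higher number from compound 2 to compound 3 (0.59 log units; beyond the scatter), while no change at the digits printed from compound 1 to compound 2 (within the scatter).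

Compound 4 `Cc1cc(S(=O)(=O)/N=C(\N)N/N=C/C#Cc2ccccc2)c(SCc2cccc3ccccc23)cc1Cl` has not yet been measured in this assay. Its structure differs from compound 3 in one place: naphthalen-1-yl in place of 4-(trifluoromethyl)phenyl on a saturated chain carbon bound to a sulfur. The two measured steps that bear on this change are the two that arrive at compound 3, and both were modest in size. Because a 3.9-fold higher number from compound 1 to compound 3 (0.59 log units; beyond the scatter) and a 3.9-fold higher number from compound 2 to compound 3 (0.59 log units; beyond the scatter), an exchange of this aromatic group has so far moved the number by a modest amount, and the two other aromatic groups tried both gave lower numbers than the 4-(trifluoromethyl)phenyl of compound 3. Going by the values given here, a step of similar, modest size is therefore expected here, most likely toward a lower number, though with only two informative steps the direction is uncertain. Compound 4 is expected to give about 25000 nM in this assay, within a range from 8000 nM to 80000 nM, which would be a 2.8-fold lower number from compound 3 to compound 4 (0.45 log units; beyond the scatter).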

Compound 4, half-maximal inhibitory concentration: 10000 nM
Compound 4: middle estimate off by 2.5-fold (0.40 log units), on the high side; measured number inside the range.
By their numbers in this assay, from the lowest: compounds 4, 1 and 2 (each within the scatter of the next); then compound 3.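

In this assay this position accepts a larger aromatic group: naphthalen-1-yl, with two six-membered aromatic rings of carbon only, replaces the single ring of 4-(trifluoromethyl)phenyl with the same count of heavy atoms, and the result is a 7.0-fold lower number from compound 3 to compound 4 (0.85 log units; beyond the scatter) and the largest step yet seen at this position. The new group also cannot be told apart from the two earlier ones, with a 1.8-fold lower number from compound 2 to compound 4 (0.26 log units; within the scatter) and a 1.8-fold lower number from compound 1 to compound 4 (0.26 log units; within the scatter) as the comparisons, so compound 1, compound 2 and compound 4 sit together while compound 3 alone stands apart as the weakest of the four. No supporting measurement is available to explain why compound 3 differs from the others.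

On these data alone, it remains open whether a different group carried in the same 4-position of the phenyl ring, such as a methyl, a chlorine or a methoxy, would behave like the 4-(trifluoromethyl)phenyl of compound 3, or whether the trifluoromethyl itself matters. Also open, as far as these compounds go, is how naphthalen-2-yl, a saturated cyclohexyl ring or a longer chain such as 2-phenylethyl would fare on this sulfur.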